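Swapping a trifluoromethyl for chloro on a urea aryl

This account rests on a few compounds, and the source may have more. Where it says the series, first, only, none or still open, it means among the compounds named here.

Of the compounds shown here, two have been tested in a functional assay on NCI-H23 cells (Homo sapiens) for inhibition, read by sulforhodamine B assay, with a stated time of 48 h, tested at 10 uM; a higher number here means a weaker effect of the compound at the concentration tested, a lower number a stronger effect. Compound 1 `COc1cc(Cl)cc(-c2nn(-c3cccc(NC(=O)c4ccc(Cl)c(Cl)c4)c3)cc2-c2ccncc2)c1` gives 75.3%, a weak effect. Compound 2 `O=C(Nc1cccc(-n2cc(-c3ccncc3)c(-c3cc(O)cc(Cl)c3)n2)c1)Nc1ccc(Cl)c(C(F)(F)F)c1` gives 10.5%, the lowest of the two numbers and beyond the scatter from compound 1. The two differ in several places, so no single step can be read from them. Compound 3 `O=C(Nc1cccc(-n2cc(-c3ccncc3)c(-c3cc(O)cc(Cl)c3)n2)c1)Nc1ccc(Cl)c(Cl)c1` differs from compound 2 in one place: chloro in place of trifluoromethyl on an aromatic carbon. Among the measured compounds shown here, no measured pair shows this change, so only a small step is expected, within the scatter, in a number 3.5 percentage points higher from compound 2 to compound 3 (within the scatter). Compound 3 is expected to give about 14%, between 3% and 40%.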

Compound 3, a percentage reported as activity, at one concentration (the size of the read-out at that concentration, not a potency): -20.5%
The estimate for compound 3 lay 34.5 percentage points above the measured number, outside the stated range (below it).
By their numbers in this assay, from the lowest: compound 3; then compound 2; then compound 1.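

At this position on the urea aryl, the change is far from neutral: in this assay the effect grows, with a number 31 percentage points lower from compound 2 to compound 3 (beyond the scatter). Replacing trifluoromethyl, with four heavy atoms, by chloro, with one, therefore strengthens the effect here, and compound 3 gives -20.5%, a value below zero. No available evidence bears on this step.

As far as these compounds go, whether a methyl group, a methoxy group or an amine at this position would read like chloro stays open. So does whether the same swap has a similar effect on the amide-linked compound 1.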